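Trifluoromethyl for fluoro in the cytotoxicity series

The source may report more compounds than this note shows. Statements on the series, on what has been measured and on what is new or still open speak of the compounds shown alone.

Values in a functional assay on V79 cells (Cricetulus griseus) for cytotoxicity, read by colony formation; a lower number here means a stronger inhibitor, a higher number a weaker inhibitor:
- compound 1 `NC1CCN(c2c(F)cc3c(=O)c(C(=O)O)cn(C4CC4)c3c2C(F)(F)F)C1`: 300 ug/mL; 300 ug/mL; 300 ug/mL (3 entries)
- compound 2 `CC1(CN)CCN(c2c(F)cc3c(=O)c(C(=O)O)cn(C4CC4)c3c2C(F)(F)F)C1`: 110 ug/mL
- compound 3 `CNCC1(C)CCN(c2c(F)cc3c(=O)c(C(=O)O)cn(C4CC4)c3c2F)C1`: 8 ug/mL

Compound 3 stands lowest at 8 ug/mL, and the nearest single number, from compound 2 at 110 ug/mL, is higher by a gap beyond the scatter. Compound 4 `CNCC1(C)CCN(c2c(F)cc3c(=O)c(C(=O)O)cn(C4CC4)c3c2C(F)(F)F)C1` has trifluoromethyl in place of fluoro on an aromatic carbon of compound 3 (trifluoromethyl in place of fluoro on an aromatic carbon). For the measured compounds named here, no step with a single change has been measured. Trifluoromethyl is also carried by compound 1 at 300 ug/mL; 300 ug/mL; 300 ug/mL (3 entries) and compound 2 at 110 ug/mL, and both numbers are higher than that of compound 3. In this assay the expected step is a rise beyond the scatter, estimated as an 8.8-fold higher number from compound 3 to compound 4 (0.94 log units; beyond the scatter). For compound 4 the estimated value is 70 ug/mL, with an expected range of 25 ug/mL to 200 ug/mL.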

Compound 4, half-maximal inhibitory concentration: 230 ug/mL
Compound 4: middle estimate off by 3.3-fold (0.52 log units), on the low side; the measured number lies above the stated range.
By their numbers in this assay, from the lowest: compound 3; then compound 2; then compound 4.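

In this assay, for the compounds shown here, the single change from fluoro to trifluoromethyl on this aromatic carbon, ortho to the 3-methyl-3-((methylamino)methyl)pyrrolidin-1-yl group, gives a large rise (a 29-fold higher number from compound 3 to compound 4 (1.46 log units; beyond the scatter)). Methyl in place of hydrogen on the amine nitrogen gives only a modest rise (a 2.1-fold higher number from compound 2 to compound 4 (0.32 log units; beyond the scatter)), so the aromatic change is the large step in this set. No measurement shown bears on the cause of either step.
Still open, as far as these compounds go, is how chloro, methyl or nitrile on this aromatic carbon would read in this assay. Also open, from the compounds shown here alone, is whether the step from fluoro to trifluoromethyl keeps its size with the amine side chains of compound 1 and compound 2.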